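The source may hold more compounds than are shown below. What is called first, only, known or untested is meant among the compounds shown, and "the series" means these compounds.

Working notes on the ester series built around the shared core of compound 1 `COCCOC(=O)C(O)Cn1cnc2c(N)ncnc21`. In a functional assay on PRK cells (Oryctolagus cuniculus) for cytotoxicity (on this read-out lower numbers stand for higher toxicity in this test and higher numbers for lower toxicity in this test), compound 1 gives > 400 ug/mL, which is a limit of the assay rather than a number. Compound 2 `CC(C)(C)OC(=O)C(O)Cn1cnc2c(N)ncnc21` also returns a limit in this assay, > 400 ug/mL. Compound 3 `CC(C)CCOC(=O)C(O)Cn1cnc2c(N)ncnc21` gives a number in this assay, 400 ug/mL. Worth noting is the limit of > 400 ug/mL in this assay, at which 2 of the 3 values shown sit. The steps among the measured compounds read as follows: a step that the two limits leave unreadable from compound 1 to compound 2; a number no higher from compound 1 to compound 3 (the limit leaves the size open); a number no higher from compound 2 to compound 3 (the limit leaves the size open). All three vary the ester alkyl group, none of them touches the methoxy of compound 1, and none has a readable size.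

Compound 4 `Nc1ncnc2c1ncn2CC(O)C(=O)OCCO` differs from compound 1 by hydrogen in place of methyl on an oxygen on a saturated carbon. Among the compounds with values here, no measured step bears directly on this position, so the expectation rests only on the flat picture across compounds 1, 2 and 3, where no step of readable size appears. Compound 4 is therefore expected to show a number no higher from compound 1 to compound 4 (the limit leaves the size open), that is, no movement beyond the scatter. The estimate for compound 4 in this assay is 400 ug/mL, spanning 200 ug/mL to 800 ug/mL, most probably reported once more as a limit.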

Compound 4, minimum cytotoxic concentration: > 400 ug/mL
Compound 4 was reported as a limit; the forecaster's own chance of this, stated with the estimate: 70%; the middle value lies on the limit itself.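

Within the data shown here, replacing methyl with hydrogen on this oxygen is the first change that touches the methoxy of compound 1, and in this assay compound 4 stays at a limit of the assay, as compound 1 does, so hydroxy in place of methoxy brings out no number here. Among these compounds, the one step with a direction is a number no lower from compound 3 to compound 4 (the limit leaves the size open), and none of the new steps can be read for size. The values in this assay gather further at one limit: the limit of > 400 ug/mL in this assay, at which 3 of the 4 values shown sit.

From the compounds shown here alone, how far compound 1, compound 2 and compound 4 lie from one another in this assay stays open, as does the size of any effect of hydroxy at this position. Whether a 2-aminoethyl group in place of 2-hydroxyethyl, or a longer chain, would give a number rather than a limit is also unresolved.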